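Replacing the methoxy group of compound 3 with hydrogen

The source may hold more compounds than are shown below. What is called first, only, known or untested is meant among the compounds shown, and "the series" means these compounds.

Values measured so far in a functional assay on HCT-15 cells (Homo sapiens) for cytotoxicity, read by sulforhodamine B assay, with a stated time of 72 h; a lower number here means a stronger inhibitor of growth, a higher number a weaker inhibitor of growth
Compound 1 (`O=C(Nc1ccc(C(F)(F)F)cc1)C1CCc2ccccc2N1`) gives 17600 nM
Compound 2 (`O=C(Nc1ccccc1C(F)(F)F)C1CCc2ccccc2N1`) gives 40400 nM
Compound 3 (`COc1ccc(NC(=O)C2CCc3ccccc3N2)cc1`) gives 50200 nM

The numbers for compound 3 and compound 2 lie within the usual scatter of each other, so these two cannot be ranked. Both numbers are higher than that of compound 1, which means weaker growth inhibition. The next compound, compound 4 (`O=C(Nc1ccccc1)C1CCc2ccccc2N1`), differs from compound 3 by a single change (hydrogen in place of methoxy on an aromatic carbon): hydrogen in place of methoxy on an aromatic carbon, para to a large group.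

Among the compounds with values here, only one measured step bears on this carbon, and it is modest (a 2.9-fold higher number from compound 1 to compound 3 (0.46 log units; beyond the scatter)). In that step, methoxy takes the place of trifluoromethyl. Within the data shown here, no measured pair shows directly what hydrogen does here, so the direction is uncertain. Among the measured compounds shown here, with only that modest step from compound 1 as a guide, a large change in this assay seems unlikely, and a slightly lower number is the most that is expected. The estimated step (a 1.3-fold lower number from compound 3 to compound 4 (0.10 log units; within the scatter)) stays within the scatter. The expected value for compound 4 is about (40000 nM), with an estimated range from (17000 nM) to (95000 nM).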

Compound 4, concentration for 50% growth inhibition: 109000 nM
Compound 4: middle estimate off by 2.7-fold (0.44 log units), on the low side, and the stated range ends below it.
By their numbers in this assay, from the lowest: compound 1; then compounds 2 and 3 (each within the scatter of the next); then compound 4.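

In this assay, hydrogen on this aromatic carbon, para to a large group, proves to be no neutral reference point, since removing methoxy gives a 2.2-fold higher number from compound 3 to compound 4 (0.34 log units; beyond the scatter), so the unsubstituted ring of compound 4 inhibits growth more weakly than its methoxy relative. Replacing trifluoromethyl on the same carbon with hydrogen gives a larger change, a 6.2-fold higher number from compound 1 to compound 4 (0.79 log units; beyond the scatter), and removing trifluoromethyl from a different carbon of that ring gives a 2.7-fold higher number from compound 2 to compound 4 (0.43 log units; beyond the scatter), so all three substituted compounds shown here inhibit growth more strongly than compound 4, with none going against this. No measurement here accounts for why a substituent of either kind lowers the number compared with hydrogen.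

These compounds leave open whether the gain over hydrogen extends to other groups on this carbon, such as a single fluorine or chlorine atom, an amine, a carboxylic acid or a longer chain. They also leave open whether methoxy on the other ring carbon used by compound 2 would give a similar gain over hydrogen.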